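The compounds below may be only part of what the source reports. "The series", "measured", "known", "first", "only" and "open" are said of these compounds alone.

In a functional assay on A549 cells (Homo sapiens) for antiproliferative activity, read by MTT assay, with a stated time of 48 h (a higher number here means a weaker inhibitor, a lower number a stronger inhibitor), compound 1 `CCCC(C)Oc1ccc(C(=O)/C=C/c2c(/C=C/c3ccc(OC)cc3)cc(OC)cc2OC)cc1` gives 9.4 ug/mL and compound 2 `CCOc1ccc(C(=O)/C=C/c2c(/C=C/c3ccc(OC)cc3)cc(OC)cc2OC)cc1` gives 7.5 ug/mL, so these two stand level within the scatter. Compound 3 `COc1ccc(/C=C/c2cc(OC)cc(OC)c2/C=C/C(=O)c2ccc(OC)cc2)cc1` differs from compound 2 by hydrogen in place of methyl on a saturated chain carbon bound to an oxygen on an aromatic ring, which turns 4-ethoxyphenyl to 4-methoxyphenyl. Among the compounds with values here, the one measured step at this place is a 1.3-fold lower number from compound 1 to compound 2 (0.10 log units; within the scatter). No change beyond the scatter is therefore expected in this assay, and the estimated step is a 1.1-fold lower number from compound 2 to compound 3 (0.03 log units; within the scatter). The estimate for compound 3 is 7 ug/mL, with an expected range of 3.5 ug/mL to 14 ug/mL.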

Compound 3, half-maximal inhibitory concentration: 4.5 ug/mL
Compound 3: the middle estimate sits 1.6-fold (0.19 log units) above what was measured, and the stated range covers the measured number.
By their numbers in this assay, from the lowest: compounds 3, 2 and 1 (each within the scatter of the next, the first and the last beyond it).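

In this assay, ethoxy to methoxy on the 4-phenyl group alone stays within the scatter (a 1.7-fold lower number from compound 2 to compound 3 (0.22 log units; within the scatter)), so this single step does not separate compound 2 from compound 3. Only the larger change at this position, from 1-methylbutyl to methyl on the oxygen, clears the scatter, and then modestly (a 2.1-fold lower number from compound 1 to compound 3 (0.32 log units; beyond the scatter)). Nothing available explains this difference. The compounds shown leave open how a hydroxyl, an amine or a carboxylic acid would read at this place, and whether a straight butyl chain would read like the branched 1-methylbutyl.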